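The compounds below may be only part of what the source reports. "The series", "measured", "known", "first", "only" and "open" are said of these compounds alone.

Measured in a functional assay on MDA-MB-231 cells (Homo sapiens) for cytotoxicity, read by MTT assay, with a stated time of 48 h; on this read-out lower numbers stand for stronger inhibition and higher numbers for weaker inhibition:
Compound 1 `Nc1ccc(NC(=O)NCCCCC(c2ccc(F)cc2)c2ccc(F)cc2)cc1`: > 20000 nM, which is a limit and not a number
Compound 2 `O=C(NCCCCC(c1ccc(F)cc1)c1ccc(F)cc1)Nc1cccc([N+](=O)[O-])c1`: 3790 nM

For the measured compounds named here, compound 2, at 3790 nM, holds the only true number in this assay so far. The one other result belongs to compound 1, which stands at the limit of > 20000 nM in this assay, at which 1 of the 2 values shown sits. Compound 3 `O=C(NCCCCC(c1ccc(F)cc1)c1ccc(F)cc1)Nc1ccc([N+](=O)[O-])c(Cl)c1` is not yet measured. It carries 3-chloro-4-nitrophenyl in place of 3-nitrophenyl on an amide-type nitrogen.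

Going by the values given here, only one measured step bears on this change. The step of an at least 5.2-fold lower number from compound 1 to compound 2 (0.72 log units; beyond the scatter) lies beyond the scatter and altered the same place, but it involved no chlorine. It therefore gives a guide to how sensitive this place is, not to direction. Compound 3 keeps a nitrophenyl group, as compound 2 at 3790 nM does, so no shift beyond the scatter is expected. The expected step is a 1.3-fold lower number from compound 2 to compound 3 (0.10 log units; within the scatter). Compound 3 is estimated at 3000 nM, with an expected range from 1000 nM to 10000 nM.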

Compound 3, half-maximal inhibitory concentration: 3470 nM
Estimate against measurement, compound 3: 1.2-fold (0.06 log units) below, within the range that was stated.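

The change from 3-nitrophenyl to 3-chloro-4-nitrophenyl gives a 1.1-fold lower number from compound 2 to compound 3 (0.04 log units; within the scatter) in this assay, so at this place on the amide-type nitrogen the two nitrophenyl groups cannot be told apart, although one carries a chlorine. The second nitrophenyl group also gives an at least 5.7-fold lower number from compound 1 to compound 3 (0.76 log units; beyond the scatter), so the difference from 4-aminophenyl now holds for two nitrophenyl groups instead of one. Compound 1 has only a limit and not a number, so the true size of both steps from it stays unknown: the limit of > 20000 nM in this assay, at which 1 of the 3 values shown sits.

The compounds shown leave open whether a phenyl group carrying chlorine alone, or a nitrile in place of the nitro group, would hold the same level. They also leave open how a longer chain on the shared core would shift the number.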